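Compound 2 to compound 3: one aryl substituent exchanged

This account rests on a few compounds, and the source may have more. Where it says the series, first, only, none or still open, it means among the compounds named here.

Of the compounds shown here, two have numbers so far in a functional assay on PC-3 cells (Homo sapiens); a higher number here means a weaker inhibitor of growth, a lower number a stronger inhibitor of growth. Compound 1 `O=S(=O)(/C=C/c1ccc(Br)cc1)Cc1ccc(Nc2ncnc3ccc(Br)cc23)cc1` gives 34000 nM. Going by the values given here, compound 2 `O=S(=O)(/C=C/c1ccc(C(F)(F)F)cc1F)Cc1ccc(Nc2ncnc3ccc(Br)cc23)cc1` gives 58000 nM, which stands within the scatter of the only other measured compound. The step between them is a 1.7-fold higher number from compound 1 to compound 2 (0.23 log units; within the scatter), with 2-fluoro-4-(trifluoromethyl)phenyl in place of 4-bromophenyl.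

Compound 3 `O=S(=O)(/C=C/c1ccc(F)cc1F)Cc1ccc(Nc2ncnc3ccc(Br)cc23)cc1` keeps everything in compound 2 except one group: fluoro in place of trifluoromethyl on an aromatic carbon. This is fluoro in place of trifluoromethyl on an aromatic carbon, meta to a fluoro group and para to a large group, and it gives 2,4-difluorophenyl. Among the compounds with values here, no measured pair carries this exact exchange. Within the data shown here, the nearest evidence is the single step in the same aryl group, and two compounds are a thin basis. The expectation of no shift beyond the scatter in this assay, and no clear direction, rests on a 1.7-fold higher number from compound 1 to compound 2 (0.23 log units; within the scatter).

For compound 3 the expected value is 42000 nM, with an estimated range of 18000 nM to 95000 nM. This estimate means an expected 1.4-fold lower number from compound 2 to compound 3 (0.14 log units; within the scatter).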

Compound 3, concentration for 50% growth inhibition: 100000 nM
Beside the measured number, compound 3's estimate is 2.4-fold (0.38 log units) below it; the measured number lies above the stated range.
By their numbers in this assay, from the lowest: compounds 1, 2 and 3 (each within the scatter of the next, the first and the last beyond it).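

In this assay the exchange of trifluoromethyl for fluoro on the aromatic carbon meta to a fluoro group and para to a large group gives a 1.7-fold higher number from compound 2 to compound 3 (0.24 log units; within the scatter) and so, read alone, does not separate compound 2 from compound 3. Going by these compounds alone, the aryl group as a whole does show a measurable difference for the first time: 2,4-difluorophenyl in place of 4-bromophenyl gives a 2.9-fold higher number from compound 1 to compound 3 (0.47 log units; beyond the scatter) and this modest step is the only one of the three beyond the scatter, while each of the other two stays within it. Nothing measured here accounts for either step, so the numbers stand without an explanation.

The aryl groups of compound 1 and compound 3 differ in more than one substituent, so the step between them cannot be assigned to the fluoro group or to the bromo group alone. Also open, going by these compounds, is whether an amine, a carboxylic acid or a longer chain on the aromatic carbon para to the large group would move the number beyond the scatter, and in which direction.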